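Purine acetamide amino acid series: step to the carbamoylmethyl analogue

This account rests on a few compounds, and the source may have more. Where it says the series, first, only, none or still open, it means among the compounds named here.

Measured so far:
- compound 1, `CC(C)[C@H](NC(=O)CN(c1nc(Cl)nc2[nH]cnc12)C1CC1)C(=O)OCc1ccccc1`; in a functional assay on the whole organism (Tail, strain ICR) with Mus musculus as the target, in the tail flick test, with a stated time of 60 min, at a dose of 25 umol/kg by the oral route (on this read-out lower numbers stand for a weaker effect and higher numbers for a stronger effect at the one dose given), compound 1 gives 55.5%.
- compound 2, `CC[C@H](C)[C@H](NC(=O)CN(c1nc(Cl)nc2[nH]cnc12)C1CC1)C(=O)O`; in this assay compound 2 gives 36%.

Compound 2 stands lowest of the two numbers in this assay. Its nearest neighbour is compound 1, whose value lies higher by a gap that is beyond the scatter. Within the data shown here, the two differ in more than one place, so the pair gives no single step and only what the two values show can be stated.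

Compound 3, `NC(=O)C[C@H](NC(=O)CN(c1nc(Cl)nc2[nH]cnc12)C1CC1)C(=O)O`, is the next compound for this assay. It differs from compound 2 in one place: carbamoylmethyl in place of sec-butyl on a saturated chain carbon bound to an amide-type nitrogen and a carbonyl carbon. Among the measured compounds shown here, no measured pair shows this change, so there is no precedent for the size of the step. With the carbamoylmethyl group entering in place of sec-butyl on a saturated chain carbon bound to an amide-type nitrogen and a carbonyl carbon, the expected step is a small move downward, at the edge of the scatter: a number 8 percentage points lower from compound 2 to compound 3 (within the scatter). For compound 3 the estimate in this assay is 28%, within a range from 10% to 48%.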

Compound 3, a percentage reported as activity, at one dose (the size of the read-out at that dose, not a potency): 43.1%
Beside the measured number, compound 3's estimate is 15.1 percentage points below it, and the stated range covers the measured number.
By their numbers in this assay, from the lowest: compounds 2 and 3 (each within the scatter of the next); then compound 1.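

In this assay, carbamoylmethyl in place of sec-butyl on a saturated chain carbon bound to an amide-type nitrogen and a carbonyl carbon gives a number 7.1 percentage points higher from compound 2 to compound 3 (within the scatter). Among these compounds, this is the first single step read at this position, and it shows that exchanging an all-carbon side chain for one holding nitrogen and oxygen, with 4 heavy atoms on each side, leaves the read-out at one dose within the scatter. No measurement shown here accounts for this step or says what the two groups do at this position.

On these data alone, one step at one dose cannot show how far this tolerance extends, so it remains open whether a side chain ending in a carboxylic acid or an amine, or a longer chain, would also stay within the scatter of compound 2. Compound 1 differs from compound 2 in more than one place, so the contribution of a benzyl ester in place of the free carboxylic acid also remains unresolved, and a matched ester and acid pair with one side chain would be needed to separate it.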